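Methoxy to bromo: a small step expected

The source may hold more compounds than are shown below. What is called first, only, known or untested is meant among the compounds shown, and "the series" means these compounds.

- compound 1 `Cc1ccc(S(=O)(=O)c2nc3ccccc3nc2N2CCCC(O)C2)cc1` (3270 nM)
- compound 2 `COc1ccc(S(=O)(=O)c2nc3ccccc3nc2N2CCCC(O)C2)cc1` (3520 nM)

Both values come from a functional assay on HCT-116 cells (Homo sapiens) for cytotoxicity, read by MTT assay, with a stated time of 72 h; on this read-out lower numbers stand for stronger inhibition and higher numbers for weaker inhibition. Compound 2 stands at 3520 nM, a value within the usual scatter of compound 1 (3270 nM), so the two cannot be ranked.

Compound 3 `O=S(=O)(c1ccc(Br)cc1)c1nc2ccccc2nc1N1CCCC(O)C1` keeps the rest of compound 2 but carries bromo in place of methoxy on an aromatic carbon, para to a large group, which turns 4-methoxyphenyl into 4-bromophenyl (bromo in place of methoxy on an aromatic carbon).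

For the measured compounds named here, one measured step bears on this change: methoxy in place of methyl on an aromatic carbon (a 1.1-fold higher number from compound 1 to compound 2 (0.03 log units; within the scatter)). That step lies within the scatter. Going by the values given here, it is thin evidence, since no compound with bromo has a measured value yet, and it does not involve bromo itself. Even so, it offers no ground for expecting a shift beyond the scatter in this assay, in either direction.

The expected step is small (a 1.2-fold lower number from compound 2 to compound 3 (0.07 log units; within the scatter)). For compound 3 the estimated value is 3000 nM (expected range 1400 nM to 6500 nM).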

Compound 3, half-maximal inhibitory concentration: 2110 nM
For compound 3 the middle estimate is 1.4-fold (0.15 log units) above the measured one; the measured number falls inside the stated range.
By their numbers in this assay, from the lowest: compounds 3, 1 and 2 (each within the scatter of the next).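

Compound 3 puts the first bromo on this aromatic carbon, para to a large group, and in this assay the exchange of methoxy for bromo reads as a 1.7-fold lower number from compound 2 to compound 3 (0.22 log units; within the scatter) while the exchange of methyl for bromo reads as a 1.5-fold lower number from compound 1 to compound 3 (0.19 log units; within the scatter). With bromo added, three groups have now been compared at this one place, methyl, methoxy and bromo, and every step among them lies within the scatter, so the earlier result for methyl and methoxy now extends to an atom of another kind, and the three compounds still cannot be ranked. Nothing measured here explains why these numbers lie so close together.

Going by these compounds, what an amine, a carboxylic acid or a longer chain such as butoxy would do at this place stays open, so it is not yet known whether any group here can move the number beyond the scatter. These three compounds also share everything outside this one place, which leaves open how much the rest of the shared core matters in this cell assay.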